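The compounds below may be only part of what the source reports. "The series", "measured", "known", "first", "only" and "open" are said of these compounds alone.

Series sharing the core of compound 3 `C[C@@H]1CN(c2cccc3c2C[C@H](CN(C)[C@H]2CCCc4cccnc42)NC3)C[C@H](C)N1C`. Within the data shown here, in a functional assay on CCRF-CEM cells for antagonist activity at C-X-C chemokine receptor type 4 (Homo sapiens), read by calcium flux, with stated times of 25 min and 90 s (on this read-out higher numbers stand for weaker inhibition and lower numbers for stronger inhibition), compound 3 gives 14.1 nM, the lowest number of the three so far; compound 1 `c1cnc2c(c1)CCC[C@@H]2N(CC1CC1)C[C@H]1Cc2c(cccc2N2CCNCC2)CN1` gives 26.7 nM, within the scatter of it, while compound 2 `CN1CCN(c2cccc3c2C[C@H](CN(C)[C@H]2CCCc4cccnc42)NC3)CC1` gives 29.6 nM. Among the measured compounds shown here, the one single-point step, a 2.1-fold lower number from compound 2 to compound 3 (0.32 log units; beyond the scatter), concerns the methyl groups on the piperazin-1-yl ring. Compound 4 `CN(C[C@H]1Cc2c(cccc2N2CCNCC2)CN1)[C@H]1CCCc2cccnc21` differs from compound 3 by piperazin-1-yl in place of 3,4,5-trimethylpiperazin-1-yl on an aromatic carbon. For the measured compounds named here, no measured step removes the methyl groups entirely; the step from compound 2 to compound 3 ran from 4-methylpiperazin-1-yl to 3,4,5-trimethylpiperazin-1-yl, and compound 1, carrying a bare piperazin-1-yl with another amine substituent, sits within the scatter of compound 3. A step back toward the value of compound 2 is expected for compound 4, a 2.0-fold higher number from compound 3 to compound 4 (0.30 log units; within the scatter). Compound 4 is estimated at 28 nM, in the range 12 nM to 65 nM.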

Compound 4, half-maximal inhibitory concentration: 6.08 nM
Compound 4: the middle estimate sits 4.6-fold (0.66 log units) above what was measured, and the stated range ends above it.
By their numbers in this assay, from the lowest: compound 4; then compounds 3, 1 and 2 (each within the scatter of the next, the first and the last beyond it).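

In this assay, methyl count on the piperazine at this aromatic carbon gives no one-way trend: adding methyls gave a 2.1-fold lower number from compound 2 to compound 3 (0.32 log units; beyond the scatter), yet the bare piperazin-1-yl gives a 2.3-fold lower number from compound 3 to compound 4 (0.37 log units; beyond the scatter) and a 4.9-fold lower number from compound 2 to compound 4 (0.69 log units; beyond the scatter). The unsubstituted ring nitrogen therefore gives the lowest number of the piperazines carrying the same amine side chain. With the bare piperazin-1-yl held, replacing the cyclopropyl on the chain carbon bound to the amine nitrogen with hydrogen gives a 4.4-fold lower number from compound 1 to compound 4 (0.64 log units; beyond the scatter). Nothing available explains these steps. Open, from the compounds shown here alone, is whether 3,5-dimethylpiperazin-1-yl or morpholin-4-yl at this carbon would match compound 4.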